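Working notes on cytotoxicity across four related compounds

This account rests on a few compounds, and the source may have more. Where it says the series, first, only, none or still open, it means among the compounds named here.

Measured so far in an ADME assay on L02 cells (Homo sapiens) for cytotoxicity, read by MTT assay, with a stated time of 24 h; on this read-out higher numbers stand for weaker inhibition and lower numbers for stronger inhibition:
compound 1 `O=C1/C(=C/c2ccncc2)CN(S(=O)(=O)c2ccc(Br)cc2)C/C1=C\c1ccccc1F`: 19400 nM
compound 2 `N#Cc1ccc(S(=O)(=O)N2C/C(=C\c3ccncc3)C(=O)/C(=C/c3ccccc3F)C2)cc1`: > 20000 nM; this is a limit of the assay, not a number.
compound 3 `O=C1/C(=C/c2ccncc2)CN(S(=O)(=O)c2ccc(Br)cc2)C/C1=C\c1ccccc1C(F)(F)F`: 12600 nM

The change cyano in place of bromo on an aromatic carbon gives an at least 1.0-fold higher number from compound 1 to compound 2 (0.01 log units; that floor lies within the scatter), the only thing known of it being (the limit of > 20000 nM in this assay, at which 1 of the 3 values shown sits). The two cores differ by trifluoromethyl in place of fluoro on an aromatic carbon, which gives a 1.5-fold lower number from compound 1 to compound 3 (0.19 log units; within the scatter). Both steps sit within the usual scatter, so neither pair can be ordered.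

Compound 4 `N#Cc1ccc(S(=O)(=O)N2C/C(=C\c3ccncc3)C(=O)/C(=C/c3ccccc3C(F)(F)F)C2)cc1` has not been measured. It differs from compound 3 by cyano in place of bromo on an aromatic carbon, the same change as made from compound 1 to compound 2, at the same place in both pairs. The expected step is a 1.3-fold higher number from compound 3 to compound 4 (0.10 log units; within the scatter) in this assay, set beside an at least 1.0-fold higher number from compound 1 to compound 2 (0.01 log units; that floor lies within the scatter), and it rests on that single measured step from compound 1 to compound 2, which was itself cut off at a limit. For compound 4 the estimate is 16000 nM, with a range from 9000 nM to 30000 nM, and a fair chance that the assay again reports only a limit.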

Compound 4, half-maximal inhibitory concentration: 17600 nM
Compound 4: the middle estimate sits 1.1-fold (0.04 log units) below what was measured; low and high end bracket the measured number.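

In this assay cyano in place of bromo gives a 1.4-fold higher number from compound 3 to compound 4 (0.15 log units; within the scatter), a step within the usual scatter, while trifluoromethyl in place of fluoro gives an at least 1.1-fold lower number from compound 2 to compound 4 (0.05 log units; that floor lies within the scatter), which is only a floor. Carried from the core of compound 1 to the core of compound 3, the cyano change gives no step beyond the scatter on the second core, but this does not show that the change keeps a fixed size from one core to another: the same change on two cores in this assay, an at least 1.0-fold higher number (0.01 log units; that floor lies within the scatter) from compound 1 to compound 2 and a 1.4-fold higher number (0.15 log units; within the scatter) from compound 3 to compound 4; the limit leaves it open whether they differ. The trifluoromethyl change stands the same way, and its size on the core of compound 2 remains unsettled: the same change on two cores in this assay, a 1.5-fold lower number (0.19 log units; within the scatter) from compound 1 to compound 3 and an at least 1.1-fold lower number (0.05 log units; that floor lies within the scatter) from compound 2 to compound 4; the limit leaves it open whether they differ.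

On these data alone, compound 2 at > 20000 nM is a limit of the assay and not a number, so how far its true value lies from the others stays open. Also open, as far as these compounds go, is whether a group of another kind in place of bromo, such as an amine or a carboxylic acid, would give a step beyond the scatter.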